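This account rests on a few compounds, and the source may have more. Where it says the series, first, only, none or still open, it means among the compounds named here.

Measured in a functional assay on OVCAR-8 cells (Homo sapiens) for antiproliferative activity; on this read-out higher numbers stand for weaker inhibition and lower numbers for stronger inhibition:
compound 1 `Cn1ncc(Cl)c1-c1cc(C(=O)N[C@H]2CNCC[C@@H]2c2ccc(C(F)(F)F)cc2)oc1Cl` gives 900 nM
compound 2 `O=C(N[C@@H]1CNCC[C@H]1c1ccc(Cl)cc1)c1ccc(-c2ncnc3c2CCC3O)s1` gives 24100 nM
compound 3 `Cn1ncc(Cl)c1-c1cc(C(=O)N[C@@H]2CN[C@H](CCO)C[C@H]2c2ccc(F)c(F)c2)oc1Cl` gives 460 nM

Compound 3 carries the lowest of the three numbers in this assay. Compound 1 lies within the usual scatter of compound 3, so no order can be drawn between those two. Compound 2 stands far above compound 3, a gap well beyond the scatter; as the two structures differ in more than one place, the numbers are all that can be said of that pair.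

Compound 4 `Cn1ncc(Cl)c1-c1cc(C(=O)N[C@@H]2CN[C@H](CCO)C[C@H]2c2ccc(Cl)c(Cl)c2)oc1Cl` has not yet been measured. It differs from compound 3 in one place:

3,4-dichlorophenyl in place of 3,4-difluorophenyl on a saturated ring carbon

For the measured compounds named here, no measured pair shows the same change, so the size of the step has to be judged from the change itself. Exchanging one pair of halogens for another on the same aromatic ring, with nothing else altered, is expected to move this assay only a little; the expected step is a 1.2-fold lower number from compound 3 to compound 4 (0.06 log units; within the scatter), with no direction that can be told apart from the scatter. For compound 4 the estimate is 400 nM, expected to fall between 150 nM and 1200 nM.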

Compound 4, half-maximal inhibitory concentration: 610 nM
Compound 4: middle estimate off by 1.5-fold (0.18 log units), on the low side; the range from low to high includes it.
By their numbers in this assay, from the lowest: compounds 3, 4 and 1 (each within the scatter of the next); then compound 2.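

In this assay, for the compounds shown here, the exchange of 3,4-difluorophenyl for 3,4-dichlorophenyl gives a 1.3-fold higher number from compound 3 to compound 4 (0.12 log units; within the scatter) and is the first reading of a change made in one place. Going by these compounds alone, on this saturated ring carbon, with the 2-hydroxyethyl group and the rest of the structure held fixed, the two halogen pairs cannot be told apart, a point the earlier compounds could not address because no two of them differed in one place only. No independent measurement bears on this result.

From the compounds shown here alone, both phenyl groups in this pair carry halogens at the same ring positions, so it remains open whether methoxy groups, nitrile groups or an unsubstituted phenyl ring at this place would also leave the number within the scatter. Also open is what the 2-hydroxyethyl group itself contributes, since no pair shown isolates it, and whether a longer chain, an amine or a carboxylic acid in its place would move the number in this assay series.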